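A few compounds are considered here, and "the series" means these few. Any claim that something is new, unique, unknown or untested is made for them only; others in the source may bear on it.

Measured so far in an assay on isolated protein (Mus musculus) for inhibition of IL15-IL15 receptor (Homo sapiens), read by resazurin assay, with stated times of 30 min and 2.5 days; a lower number here means a stronger inhibitor, a higher number a weaker inhibitor:

- compound 1 `Cn1c(Cc2nn(C)c(=O)c3ccccc23)nnc1SCCCCCCCC(=O)Nc1ccc(Cl)cc1Cl`: 1900 nM
- compound 2 `CN(C(=O)CCCCCCCSc1nnc(Cc2nn(C)c(=O)c3ccccc23)n1C)c1ccc(Cl)cc1Cl`: 11900 nM
- compound 3 `Cn1c(Cc2nn(C)c(=O)c3ccccc23)nnc1SCCCCCCCC(=O)Oc1ccc(Cl)cc1Cl`: 800 nM

Compound 3 gives the lowest number of the three in this assay. The nearest neighbour is compound 1, separated by the step of a 2.4-fold lower number from compound 1 to compound 3 (0.38 log units; beyond the scatter); the furthest is compound 2, separated by the step of a 15-fold lower number from compound 2 to compound 3 (1.17 log units; beyond the scatter). Within the anilide pair, the step of a 6.3-fold higher number from compound 1 to compound 2 (0.80 log units; beyond the scatter) shows that methylation of the amide nitrogen costs clearly.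

Compound 4 `Cc1ccc(NC(=O)CCCCCCCSc2nnc(Cc3nn(C)c(=O)c4ccccc34)n2C)c(Cl)c1` differs from compound 3 by (2-chloro-4-methylphenyl)amino in place of 2,4-dichlorophenoxy on a carbonyl carbon. Two things change at once: the ester returns to an anilide bearing an amide hydrogen, and one chlorine on the ring is exchanged for a methyl. Only the first part is covered by a measured pair: the step of a 2.4-fold lower number from compound 1 to compound 3 (0.38 log units; beyond the scatter) ran in the opposite direction, ester in place of anilide, and was modest. Reversing it points to a modest rise in this assay for compound 4. Among the measured compounds shown here, the exchange of chlorine for methyl on the ring has no measured counterpart here, so its contribution is unknown and widens the range.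

Compound 4 is therefore expected to give a modestly higher number than compound 3, a step of about a 2.5-fold higher number from compound 3 to compound 4 (0.40 log units; beyond the scatter), landing near the value of compound 1. The estimate for compound 4 in this assay is 2000 nM, with a range from 700 nM to 6000 nM.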

Compound 4, half-maximal inhibitory concentration: 2300 nM
Compound 4: middle estimate off by 1.2-fold (0.06 log units), on the low side; the range from low to high includes it.
By their numbers in this assay, from the lowest: compound 3; then compounds 1 and 4 (each within the scatter of the next); then compound 2.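

In this assay, among the compounds shown here, the chloro-to-methyl exchange on an aromatic carbon, the one part of this change with no earlier counterpart, can now be read on its own, and it stays within the scatter (a 1.2-fold higher number from compound 1 to compound 4 (0.08 log units; within the scatter)). With that exchange making no measurable difference between these two anilides, the step back from the ester (a 2.9-fold higher number from compound 3 to compound 4 (0.46 log units; beyond the scatter)) reads as the reverse of the earlier ester-for-anilide step (a 2.4-fold lower number from compound 1 to compound 3 (0.38 log units; beyond the scatter)), which places the ester-anilide difference at the carbonyl carbon rather than on the ring substituent. The (2-chloro-4-methylphenyl)amino group also keeps its advantage over the (2,4-dichlorophenyl)(methyl)amino group (a 5.2-fold lower number from compound 2 to compound 4 (0.71 log units; beyond the scatter)), in line with the cost of methylating the amide nitrogen, although no measurement here explains any of these steps.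

Still open, from the compounds shown here alone, is whether the silence of the chloro-to-methyl exchange extends to other groups on that aromatic carbon, such as fluoro, methoxy or plain hydrogen. Also open, going by these compounds, is how a ketone, a carboxylic acid or a primary amide at the carbonyl carbon, or a shorter chain, would compare with the ester and the anilides.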